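A few compounds are considered here, and "the series" means these few. Any claim that something is new, unique, unknown or untested is made for them only; others in the source may bear on it.

Compound 1 `C/C(=C\Cc1c(O)ccc2c1O[C@H](c1ccc(O)cc1)CC2=O)C/C=C/C(C)(C)O` and compound 2 `COC(C)(C)/C=C/C/C(C)=C/Cc1c(O)ccc2c1O[C@H](c1ccc(O)cc1)CC2=O` share one core and differ only in one side-chain oxygen. In a functional assay on HepG2 cells (Homo sapiens) for cytotoxicity, read by MTT assay (on this read-out lower numbers stand for stronger inhibition and higher numbers for weaker inhibition), compound 1 gives > 10000 nM, which is a limit of the assay rather than a number. Compound 2 gives > 10000 nM in this assay, also a limit. The step that the two limits leave unreadable from compound 1 to compound 2 therefore cannot be read. Compound 3 `C=C(C)C(O)CC/C(C)=C/Cc1c(O)ccc2c1O[C@H](c1ccc(O)cc1)CC2=O` differs from compound 2 by 2-hydroxy-3-methylbut-3-en-1-yl in place of 3-methoxy-3-methylbut-1-en-1-yl on a saturated chain carbon bound to a double-bonded chain carbon. No readable measured step bears on this change, and both values shown sit at the limit of > 10000 nM in this assay, at which 2 of the 2 values shown sit. Compound 3 is expected to stay near that limit, so the estimated step that the limit leaves unreadable from compound 2 to compound 3 is small. Compound 3 is estimated at 20000 nM, between 5000 nM and 80000 nM.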

Compound 3, half-maximal inhibitory concentration: > 10000 nM
Compound 3 gave a limit, no number; the forecaster's own chance of this, stated with the estimate: 70%; the middle value does not contradict the limit.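

No step among compound 1, compound 2 and compound 3 can be read, as all three give a limit and not a number: the limit of > 10000 nM in this assay, at which 3 of the 3 values shown sit.

As far as these compounds go, what stays open is how strongly any of them acts in this assay, and whether these side-chain changes matter there at all.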